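The source may hold more compounds than are shown below. What is called first, only, known or untested is meant among the compounds shown, and "the series" means these compounds.

In a functional assay on MGC-803 cells (Homo sapiens) for inhibition, read by CCK-8 assay, with a stated time of 48 h (a higher number here means a weaker inhibitor, a lower number a stronger inhibitor), compound 1 `CCN1CCN(C(=S)SCC(=O)N(Cc2ccc(OC)cc2)c2cc(OC)c(OC)c(OC)c2)CC1` stands higher of the two measured compounds at 9890 nM and compound 2 `COc1ccc(CN(C(=O)CSC(=S)N2CCN(C(=O)OC(C)(C)C)CC2)c2cc(OC)c(OC)c(OC)c2)cc1` gives 310 nM. Compound 3 `COc1ccc(CN(C(=O)CSC(=S)N2CCc3ccccc32)c2cc(OC)c(OC)c(OC)c2)cc1` has not yet been measured. Its change from compound 1 is 2,3-dihydro-1H-indol-1-yl in place of 4-ethylpiperazin-1-yl on a thiocarbonyl carbon, so 2,3-dihydro-1H-indol-1-yl takes the place of 4-ethylpiperazin-1-yl on a thiocarbonyl carbon. Going by the values given here, the one measured step that bears on this is a 32-fold lower number from compound 1 to compound 2 (1.50 log units; beyond the scatter), which is large and beyond the scatter, with tert-butoxycarbonyl in place of ethyl on an amine nitrogen in a ring. Among the compounds with values here, that step keeps the ring, whereas compound 3 replaces it, and no measured compound carries the new group, so the guide is a loose one. With only a 32-fold lower number from compound 1 to compound 2 (1.50 log units; beyond the scatter) to go on, a lower number is expected in this assay, though by a smaller step. The estimated step is a 9.9-fold lower number from compound 1 to compound 3 (1.00 log units; beyond the scatter). Compound 3 is estimated at 1000 nM, with an expected range from 150 nM to 6000 nM.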

Compound 3, half-maximal inhibitory concentration: 8410 nM
Estimate against measurement, compound 3: 8.4-fold (0.92 log units) below; measured number outside the range, above it.
By their numbers in this assay, from the lowest: compound 2; then compounds 3 and 1 (each within the scatter of the next).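

In this assay, replacing the whole ring system at the thiocarbonyl carbon gives a 1.2-fold lower number from compound 1 to compound 3 (0.07 log units; within the scatter), so 4-ethylpiperazin-1-yl and 2,3-dihydro-1H-indol-1-yl cannot be told apart here, even though they differ in ring size, in ring type and in the presence of an aromatic ring. The large change seen with a 32-fold lower number from compound 1 to compound 2 (1.50 log units; beyond the scatter) is therefore not repeated by every change made at this place, and this one exchange of groups leaves the number where it was. Nothing available explains why these two groups read alike.

As far as these compounds go, it remains open whether the gain with tert-butoxycarbonyl needs that whole group or would also appear with a smaller acetyl group on the same ring nitrogen. A piperazine with a free amine, or a morpholine ring, would also test how much the ring itself matters.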